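This account rests on a few compounds, and the source may have more. Where it says the series, first, only, none or still open, it means among the compounds named here.

Compound 1, `C=CCOc1c(C)c(C)c2c(c1C)CCC(C)(COc1ccc(/C=C3\SC(=O)NC3=O)cc1OC)O2`, gives 34% in a functional assay on MCF7 cells (Homo sapiens), tested at 2.5 uM; a higher number here means a weaker effect of the compound at the concentration tested, a lower number a stronger effect. Compound 2, `COc1cc(/C=C2\SC(=O)NC2=O)ccc1OCC1(C)CCc2c(C)c(OCC=C(C)C)c(C)c(C)c2O1`, gives 95% in this assay. Compound 3, `C=CCOc1c(C)c(C)c2c(c1C)CCC(C)(COc1ccc(/C=C3\SC(=O)NC3=O)cc1Br)O2`, gives 102% in this assay.

Compound 2 differs from compound 1 by 2-methylprop-1-en-1-yl in place of vinyl on a saturated chain carbon bound to an oxygen on an aromatic ring, and this change produced a number 61 percentage points higher from compound 1 to compound 2 (beyond the scatter). The two cores differ by bromo in place of methoxy on an aromatic carbon, which brought a number 68 percentage points higher from compound 1 to compound 3 (beyond the scatter). The values of compound 2 and compound 3 lie within the scatter of each other, so nothing about their order can be read from them.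

Compound 4, `CC(C)=CCOc1c(C)c(C)c2c(c1C)CCC(C)(COc1ccc(/C=C3\SC(=O)NC3=O)cc1Br)O2`, has not yet been measured in this assay. It differs from compound 3 by 2-methylprop-1-en-1-yl in place of vinyl on a saturated chain carbon bound to an oxygen on an aromatic ring, the same change that carried compound 1 to compound 2. Because compound 3 already shows 102%, little room for a further rise remains, and the step is expected to be about a number 2 percentage points lower from compound 3 to compound 4 (within the scatter). Compound 4 is therefore estimated to give 100% in this assay, most likely between 85% and 115%.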

Compound 4, a percentage reported as activity, at one concentration (the size of the read-out at that concentration, not a potency): 96%
Compound 4: middle estimate off by 4 percentage points, on the high side; the range from low to high includes it.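

On the core carrying bromo, the change from allyloxy to (3-methylbut-2-en-1-yl)oxy gave a number 6 percentage points lower from compound 3 to compound 4 (within the scatter), so the large step seen on the core of compound 1 did not carry over: the same change on two cores in this assay, a number 61 percentage points higher (beyond the scatter) from compound 1 to compound 2 and a number 6 percentage points lower (within the scatter) from compound 3 to compound 4, 67 percentage points apart, beyond the scatter of two such steps. Bromo in place of methoxy behaved the same way, giving a number 1 percentage points higher from compound 2 to compound 4 (within the scatter) on the core carrying (3-methylbut-2-en-1-yl)oxy, and its large step on the core of compound 1 did not carry over either: the same change on two cores in this assay, a number 68 percentage points higher (beyond the scatter) from compound 1 to compound 3 and a number 1 percentage points higher (within the scatter) from compound 2 to compound 4, 67 percentage points apart, beyond the scatter of two such steps. In this assay the two changes therefore do not add up as fixed increments among these four compounds, with only compound 1 standing apart at 34%, but this does not show why the steps depend on the core, nor whether the same would hold at another concentration or in another series.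

The compounds shown leave open whether another group on that aromatic carbon, such as chloro or ethoxy, would keep the number of compound 1. They also leave open what a saturated chain, such as propyl in place of allyl, would do.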